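This account rests on a few compounds, and the source may have more. Where it says the series, first, only, none or still open, it means among the compounds named here.

The series rests on a shared core, shown for compound 1 as `O=C(/C=C/c1ccc(O)c(O)c1[N+](=O)[O-])OCCc1ccccc1`. In a functional assay on BeWo cells (Homo sapiens) for inhibition, read by MTT assay (on this read-out higher numbers stand for weaker inhibition and lower numbers for stronger inhibition), compound 1 gives 4380 nM. Compound 2, `O=C(/C=C/c1cc(O)c(O)c([N+](=O)[O-])c1)OCCc1ccccc1`, also carries a nitro group, but for compound 2 the entry in this assay reads "not determined" (no result reported), so no result was reported. Compound 3, `O=C(/C=C/c1cc(O)c(O)c(Cl)c1)OCCc1ccccc1`, carries a chloro in place of the nitro group, and for compound 3 the entry in this assay likewise reads "not determined" (no result reported), so no result was reported. Compound 3 therefore stands without a number; compound 2 is in the same position, and the only measured anchor in the series is compound 1 at 4380 nM.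

Compound 4 is `O=C(/C=C/c1cc(O)c(O)c(Br)c1)OCCc1ccccc1`. It differs from compound 3 in one place: bromo in place of chloro on an aromatic carbon. Within the data shown here, no measured pair of this kind exists in the set, so no step size is known from data. The expectation is that bromo in place of chloro on this aromatic carbon moves the result in this assay by no more than the usual scatter, with no direction stated. Resting on compound 1 alone, compound 4 is estimated at 5000 nM, with a range from 1500 nM to 16000 nM. A limit rather than a number is possible for compound 4.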

Compound 4, half-maximal inhibitory concentration: 8240 nM
Compound 4: middle estimate off by 1.6-fold (0.22 log units), on the low side; low and high end bracket the measured number.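

Compound 4 gives 8240 nM and compound 3 has no reported result in this assay so no step can be read between compound 3 and compound 4. The compounds shown leave open how bromo and chloro compare on this aromatic carbon, and how either compares with the nitro group of compound 2. No evidence at hand bears on this result.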